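A few compounds are considered here, and "the series" means these few. Any claim that something is new, unique, unknown or untested is made for them only; others in the source may bear on it.

Measured so far:
Compound 1 `O=C(NC(=O)c1ccccc1O)c1ccc(-c2ccccc2)cc1`: > 100 ug/mL (a limit)
Compound 2 `COC(=O)c1ccc(C(=O)NC(=O)c2ccccc2O)cc1`: 42 ug/mL
Compound 3 `COc1ccc(C(=O)NC(=O)c2ccccc2O)cc1`: 39 ug/mL

In an ADME assay on L6 cells (Rattus norvegicus) for cytotoxicity, read by resazurin assay, with a stated time of 72 h (on this read-out lower numbers stand for stronger inhibition and higher numbers for weaker inhibition), only two of these compounds have a number, and they lie within the scatter of each other: the data show a 1.1-fold lower number from compound 2 to compound 3 (0.03 log units; within the scatter). Compound 1 sits at a limit of the assay, > 100 ug/mL.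

Compound 4 `COC(=O)CCC(=O)Nc1ccc(C(=O)NC(=O)c2ccccc2O)cc1` has ((2-(methoxycarbonyl)ethyl)carbonyl)amino in place of methoxy on an aromatic carbon, para to a large group: ((2-(methoxycarbonyl)ethyl)carbonyl)amino in place of methoxy on an aromatic carbon. All three measured steps bear on this place. Replacing phenyl gave an at least 2.3-fold lower number from compound 1 to compound 2 (0.37 log units; beyond the scatter) and an at least 2.5-fold lower number from compound 1 to compound 3 (0.40 log units; beyond the scatter), both beyond the scatter. Exchanging the two groups without a ring gave only a 1.1-fold lower number from compound 2 to compound 3 (0.03 log units; within the scatter). The entering group also has no ring, so the last of these steps is the closest guide, and no step beyond the scatter is expected. The expected change is a 1.2-fold higher number from compound 3 to compound 4 (0.06 log units; within the scatter). The estimate for compound 4 is 45 ug/mL, with an expected range from 18 ug/mL to 100 ug/mL.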

Compound 4, half-maximal inhibitory concentration: > 50 ug/mL
Compound 4: no number, only a limit; the forecaster's own chance of this, stated with the estimate: 15%; middle value at least 1.1-fold (0.04 log units) away from the limit.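

In this assay compound 4 gives > 50 ug/mL, which is a limit and not a number: the limit of > 50 ug/mL in this assay, at which 1 of the 4 values shown sits. The change at this aromatic carbon thus shows an at least 1.2-fold higher number from compound 3 to compound 4 (0.10 log units; that floor lies within the scatter) and an at least 1.1-fold higher number from compound 2 to compound 4 (0.07 log units; that floor lies within the scatter), so the ((2-(methoxycarbonyl)ethyl)carbonyl)amino group, much larger than methoxy or methoxycarbonyl and also without a ring, brings no lower number, though neither floor shows a rise beyond the scatter. The step between the two limits, from compound 1 to compound 4, cannot be read.

As far as these compounds go, how far the true value of compound 4 lies past its limit remains open, and with it whether this group truly differs from methoxy. Also open, from the compounds shown here alone, is what a simple amine at this place, or a carboxylic acid at the end of the chain in place of the methyl ester, would give.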